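Chloro on the aryl ketone of a phthalimide-triazole thioether

The source may hold more compounds than are shown below. What is called first, only, known or untested is meant among the compounds shown, and "the series" means these compounds.

Measured compounds:
Compound 1, `Cc1nnc(SCC(=O)c2ccc(Cl)cc2)n1N1C(=O)c2ccccc2C1=O`, in a functional assay on PC-3M cells (Homo sapiens) for cytotoxicity, read by MTT assay, with a stated time of 48 h; a lower number here means a stronger inhibitor, a higher number a weaker inhibitor: > 200000 nM
Compound 2, `CCc1nnc(SCC(=O)c2ccccc2)n1N1C(=O)c2ccccc2C1=O`, in this assay: > 200000 nM

Both measured values are limits of the assay rather than numbers. Compound 2 sits at the limit > 200000 nM, so no real potency is known for it. Compound 1 likewise sits at a limit, > 200000 nM. Every value shown is a limit (the limit of > 200000 nM in this assay, at which 2 of the 2 values shown sit), so compound 2 cannot be placed above or below anything.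

Compound 3, `CCc1nnc(SCC(=O)c2ccc(Cl)cc2)n1N1C(=O)c2ccccc2C1=O`, differs from compound 2 by one change: chloro in place of hydrogen on an aromatic carbon. Compound 1 already carries this chloro and reaches only a limit, > 200000 nM, so no step beyond the scatter is expected in this assay from this change; the result is expected to be another limit. Compound 3 is estimated at 300000 nM, within 150000 nM to 1000000 nM, a step from compound 2 of a step that the limit leaves unreadable from compound 2 to compound 3 being expected.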

Compound 3, half-maximal inhibitory concentration: > 200000 nM
Compound 3: only a limit was reported; the forecaster's own chance of this, stated with the estimate: 85%; the middle value is on the limit's open side.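

Going by these compounds alone, compound 3, like compound 1 and compound 2, gives only a limit and not a number, so no step from compound 2 or compound 1 to compound 3 can be read: the limit of > 200000 nM in this assay, at which 3 of the 3 values shown sit.

The compounds shown leave open what potency any of them has, and whether the chloro or the added methyl changes it at all.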